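Amide Nitrogen Variation on a Shared Dimethoxy Core

This account rests on a few compounds, and the source may have more. Where it says the series, first, only, none or still open, it means among the compounds named here.

Compound 1, `COc1cc2c(cc1OC)C(CC(N)=O)CC2`: 27.8% in a functional assay on the whole organism (strain Wistar) for inhibition, with Rattus norvegicus as the target, read by paw edema, with stated times of 60 min and 6 h, at a dose of 100 mg/kg by the oral route; a lower number here means less inhibition, a higher number more inhibition at the dose given (going by the name of the read-out).
Compound 2, `COc1cc2c(cc1OC)C(CC(=O)NC(C)C)CC2`: 37% in this assay.
Compound 3, `CCCCCCNC(=O)CC1CCc2cc(OC)c(OC)cc21`: 38.3% in this assay.

Compound 2 stands second highest of the three numbers in this assay. Its nearest neighbour is compound 3, with a number 1.3 percentage points higher from compound 2 to compound 3 (within the scatter), and its furthest is compound 1, with a number 9.2 percentage points higher from compound 1 to compound 2 (within the scatter). Both gaps lie within the scatter, so the three amides cannot be put in order on these numbers; only a number 10.5 percentage points higher from compound 1 to compound 3 (beyond the scatter) reaches beyond it, and then modestly.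

Compound 4, `COc1cc2c(cc1OC)C(CC(=O)N1CCCC1)CC2`, differs from compound 2 by pyrrolidin-1-yl in place of isopropylamino on a carbonyl carbon. The measured steps that bear on this change are those that alter the group on the amide-type nitrogen: a number 9.2 percentage points higher from compound 1 to compound 2 (within the scatter), a number 10.5 percentage points higher from compound 1 to compound 3 (beyond the scatter) and a number 1.3 percentage points higher from compound 2 to compound 3 (within the scatter). Going by the values given here, all are small, and the one that exchanges one carbon group for another lies within the scatter. Among the compounds with values here, no measured compound carries a ring on this nitrogen, and none lacks a hydrogen-bond donor there, so the data give no direct guide on that part of the change. On these grounds compound 4 is expected to sit close to compound 2 and compound 3, with no change at the digits printed from compound 2 to compound 4 (within the scatter) expected to stay within the scatter. The estimate for compound 4 in this assay is 37%, with a range from 24% to 50%.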

Compound 4, a percentage reported as inhibition, in the whole organism at one dose (the size of the read-out at that dose, not a potency): 22.2%
Compound 4: middle estimate off by 14.8 percentage points, on the high side, outside the stated range (below it).
By their numbers in this assay, from the lowest: compounds 4, 1, 2 and 3 (each within the scatter of the next, the first and the last beyond it).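

Pyrrolidin-1-yl on the carbonyl carbon gives the first step in this set to a lower number beyond the scatter in this assay, with a number 14.8 percentage points lower from compound 2 to compound 4 (beyond the scatter) and a number 16.1 percentage points lower from compound 3 to compound 4 (beyond the scatter), so this position does respond to the change, even though exchanging hexyl for isopropyl on the nitrogen had left the number within the scatter. Against the unsubstituted amide the picture is less clear: a number 5.6 percentage points lower from compound 1 to compound 4 (within the scatter), so compound 4 cannot be set apart from compound 1, and only the two alkyl amides, compound 2 and compound 3, stand clear of compound 4. Nothing in the information available explains this drop.

The change from isopropylamino to pyrrolidin-1-yl introduces a five-membered ring and removes the hydrogen-bond donor together, so the compounds shown cannot separate these two differences. As far as these compounds go, a diethylamino group, open-chain with no amide hydrogen, and a piperidin-1-yl ring would bear on that question, and whether the lower number holds at other doses also remains open.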